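Three Near-Identical Values and a Methoxy Analogue

The compounds below may be only part of what the source reports. "The series", "measured", "known", "first", "only" and "open" are said of these compounds alone.

Compound 1, `CCOC(=O)/C=C1/C(=O)Nc2ccccc21`, gives 78.3% in a functional assay on SW480 cells (Homo sapiens) for inhibition, read by CCK-8 assay, with a stated time of 72 h, tested at 20 uM; on this read-out higher numbers stand for more inhibition of growth at the one concentration tested and lower numbers for less inhibition of growth.
Compound 2, `CC(C)(C)OC(=O)/C=C1/C(=O)Nc2ccccc21`, gives 78.1% in this assay.
Compound 3, `CC(C)c1ccc2c(c1)/C(=C\C(=O)OC(C)(C)C)C(=O)N2`, gives 78.5% in this assay.

Compound 3 carries the highest number of the three, but only by amounts that fall within the scatter of this assay: the values of compound 1 and compound 3 sit almost on top of each other, and the step of a number 0.4 percentage points higher from compound 2 to compound 3 (within the scatter) is likewise within scatter. The step of a number 0.2 percentage points lower from compound 1 to compound 2 (within the scatter) shows the same picture, so the three measured compounds are indistinguishable on this read-out.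

Compound 4, `COc1ccc2c(c1)/C(=C\C(=O)OC(C)(C)C)C(=O)N2`, differs from compound 3 in one place: methoxy in place of isopropyl on an aromatic carbon. Among the measured compounds shown here, the only measured step at this aromatic carbon is the step of a number 0.4 percentage points higher from compound 2 to compound 3 (within the scatter), which was within scatter, and the one change elsewhere was also within scatter. No step beyond the scatter is therefore expected in this assay, in either direction. Compound 4 is expected to give 78% in this assay, estimated between 68% and 88%. This corresponds to an expected step of a number 0.5 percentage points lower from compound 3 to compound 4 (within the scatter).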

Compound 4, percent growth inhibition at one concentration: 78.7%
For compound 4 the middle estimate is 0.7 percentage points below the measured one; the measured number falls inside the stated range.
By their numbers in this assay, from the lowest: compounds 2, 1, 3 and 4 (each within the scatter of the next).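

At this aromatic carbon, a change from a carbon-only group to one holding an oxygen, and with it a hydrogen-bond acceptor, gives a number 0.2 percentage points higher from compound 3 to compound 4 (within the scatter) in this assay. Set against the unsubstituted parent, methoxy in place of hydrogen gives a number 0.6 percentage points higher from compound 2 to compound 4 (within the scatter), so hydrogen, isopropyl and methoxy at this carbon cannot be told apart on this read-out, which extends the earlier flat picture to a second kind of substituent. No available evidence accounts for this flatness.

The compounds shown leave open whether an amine, a carboxylic acid or a longer alkyl chain at this carbon would produce a step beyond the scatter. They also leave open whether these four compounds, alike at the one concentration tested, would separate at other concentrations.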